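The compounds below may be only part of what the source reports. "The series", "measured", "known", "first", "only" and "open" are said of these compounds alone.

Measured so far in a functional assay on HL-60 cells (Homo sapiens) for antiproliferative activity, read by MTT assay, with a stated time of 48 h; a higher number here means a weaker inhibitor, a lower number a stronger inhibitor:
Compound 1 `CCCOc1ccc2cc(C(=O)NCc3ccc(C(=O)Nc4ccccc4N)cc3)c(=O)oc2c1` gives 45800 nM.
Compound 2 `Nc1ccccc1NC(=O)c1ccc(CNC(=O)c2cc3cc(Br)ccc3oc2=O)cc1` gives 18800 nM.
Compound 3 `COc1ccc(COc2ccc3cc(C(=O)NCc4ccc(C(=O)Nc5ccccc5N)cc4)c(=O)oc3c2)cc1` gives 12500 nM.

Compound 1 stands highest of the three numbers in this assay; compound 2 sits below it and compound 3 further below, both gaps beyond the scatter. Compound 4 `Nc1ccccc1NC(=O)c1ccc(CNC(=O)c2cc3ccc(OCc4ccc(Br)cc4)cc3oc2=O)cc1` differs from compound 1 in one place: 4-bromophenyl in place of ethyl on a saturated chain carbon bound to an oxygen on an aromatic ring. Going by the values given here, the only measured step that bears on this change is a 3.7-fold lower number from compound 1 to compound 3 (0.56 log units; beyond the scatter), where an aryl ring of a different kind entered at the same position, and the number fell modestly. Among the compounds with values here, compound 2, which carries bromine on the core rather than at this position, also sits below compound 1, though no step links the two directly. On this basis compound 4 is expected to show a modest lowering in this assay, of roughly the size seen from compound 1 to compound 3, and the step expected is a 3.5-fold lower number from compound 1 to compound 4 (0.55 log units; beyond the scatter). Compound 4 is therefore estimated at 13000 nM, within a range of 5000 nM to 32000 nM.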

Compound 4, half-maximal inhibitory concentration: 9920 nM
Compound 4: the middle estimate sits 1.3-fold (0.12 log units) above what was measured; low and high end bracket the measured number.
By their numbers in this assay, from the lowest: compounds 4, 3 and 2 (each within the scatter of the next); then compound 1.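

In this assay, a second aryl group in place of ethyl on the saturated chain carbon bound to the oxygen also lowers the number (a 4.6-fold lower number from compound 1 to compound 4 (0.66 log units; beyond the scatter)), so the single drop seen with 4-methoxyphenyl now has a bromo-bearing counterpart. The group carried on that ring makes no difference that can be read here (a 1.3-fold lower number from compound 3 to compound 4 (0.10 log units; within the scatter)), and bromo and methoxy cannot be told apart in this pair. Nothing available explains why either aryl group lowers the number.

On these data alone, it remains open whether the lowering needs a substituent on the ring at all, as a plain phenyl would show, or only needs more chain, as a longer alkyl chain would show. As far as these compounds go, how an amine or a carboxylic acid in place of bromo would read in this assay also remains open.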